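A few compounds are considered here, and "the series" means these few. Any claim that something is new, unique, unknown or untested is made for them only; others in the source may bear on it.

In a functional assay on cells (Homo sapiens) for antiproliferative activity, read by WST assay, with a stated time of 3 days (a lower number here means a stronger inhibitor, a higher number a weaker inhibitor), compound 1 `N#Cc1cc(=O)[nH]c(=O)n1[C@@H]1O[C@H](CO)[C@@H](O)[C@H]1O` gives > 50000 nM, which is a limit and not a number. Compound 2 `CN(C)c1cc(=O)[nH]c(=O)n1[C@@H]1O[C@H](CO)[C@@H](O)[C@H]1O` gives > 50000 nM, also a limit. So compound 2 has no measured potency to start from, and the whole record so far is the limit of > 50000 nM in this assay, at which 2 of the 2 values shown sit. Within the data shown here, the only measured step is a step that the two limits leave unreadable from compound 1 to compound 2, which offers no size to carry forward.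

Compound 3 `O=c1cc(NO)n([C@@H]2O[C@H](CO)[C@@H](O)[C@H]2O)c(=O)[nH]1` has hydroxyamino in place of dimethylamino on an aromatic carbon. With no measured activity in this series, the expectation is for little change, and another limit is quite possible. If a number does appear, it should lie only modestly on the stronger side of the limit in this assay. The expected change is an at least 1.6-fold lower number from compound 2 to compound 3 (0.22 log units; that floor lies within the scatter). Compound 3 is estimated at 30000 nM, with an expected range of 5000 nM to 50000 nM.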

Compound 3, half-maximal inhibitory concentration: > 50000 nM
Compound 3: only a limit was reported; the forecaster's own chance of this, stated with the estimate: 65%; at least 1.6-fold (0.22 log units) between middle value and limit.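

Compound 3 gives > 50000 nM, which is a limit. Among these compounds, its steps from compound 1 and from compound 2 cannot be read, so no new step emerges. The compounds shown leave open whether any of these groups changes potency, since all share one result: the limit of > 50000 nM in this assay, at which 3 of the 3 values shown sit.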